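Ring in Place of a Hydroxy Chain

This account rests on a few compounds, and the source may have more. Where it says the series, first, only, none or still open, it means among the compounds named here.

Compound 1 `Nc1ncnc2c1ncn2CC#CCCl` gives 90000 nM
Compound 2 `Nc1ncnc2c1ncn2CC#CCO` gives 490000 nM
Compound 3 `Nc1ncnc2c1ncn2/C=C/CCO` gives 100000 nM

These three values come from a functional assay on L1210 cells (Mus musculus) for inhibition; a lower number here means a stronger inhibitor, a higher number a weaker inhibitor. There, compound 3 cannot be told apart from compound 1, and both stand under compound 2. The measured comparison shows a 1.1-fold higher number from compound 1 to compound 3 (0.05 log units; within the scatter), while the other comparison for this molecule shows a 4.9-fold lower number from compound 2 to compound 3 (0.69 log units; beyond the scatter).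

The next molecule is compound 4 `Nc1ncnc2c1ncn2C1C=CCO1`, and the change is a group of 5 heavy atoms (4 carbon, 1 oxygen; one five-membered non-aromatic ring with 1 hetero atom) in place of a group of 5 heavy atoms (4 carbon, 1 oxygen; no ring), on an aromatic nitrogen. The 4-hydroxybut-1-en-1-yl chain leaves, and the entering group brings one five-membered non-aromatic ring and 0 hydrogen-bond donors.

Among the compounds with values here, no measured step introduces a ring, so the guidance is indirect. Swapping one group on this core has produced modest shifts, such as a 5.4-fold higher number from compound 1 to compound 2 (0.74 log units; beyond the scatter). Compound 1 carries no hydroxy, yet its value of 90000 nM sits within the scatter of compound 3, so losing the hydroxy need not move the number much. Modest shifts in either direction therefore remain possible, but no clear one can be predicted.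

The expected step is a 1.5-fold higher number from compound 3 to compound 4 (0.18 log units; within the scatter), which would not be a clear change.

For compound 4 the estimated value is 150000 nM, with an expected range from 50000 nM to 450000 nM.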

Compound 4, half-maximal inhibitory concentration: > 500000 nM
Compound 4: no number, only a limit (the forecaster's own chance of this, stated with the estimate: 15%); middle value at least 3.3-fold (0.52 log units) from the limit.
By their numbers in this assay, from the lowest: compounds 1 and 3 (each within the scatter of the next); then compound 2. At a limit, above all of these: compound 4.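

Compound 4 gives only a limit, not a number: the limit of > 500000 nM in this assay, at which 1 of the 4 values shown sits. On this aromatic nitrogen, the five-membered non-aromatic ring enters in place of an open chain, and the comparison with the 4-hydroxybut-1-en-1-yl chain shows an at least 5.0-fold higher number from compound 3 to compound 4 (0.69 log units; beyond the scatter). The comparison with the chloro chain shows an at least 5.5-fold higher number from compound 1 to compound 4 (0.74 log units; beyond the scatter). Compound 1 has no hydroxy either, yet its value cannot be told apart from that of compound 3, so losing the hydrogen-bond donor of the hydroxy does not by itself go with a weaker result, while replacing these open chains with the ring does. The comparison with the remaining chain shows an at least 1.0-fold higher number from compound 2 to compound 4 (0.00 log units; that floor lies within the scatter), so no clear change can be read from it.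

The compounds shown do not separate the effect of the ring itself from that of its oxygen or its double bond, so a saturated five-membered ring or an all-carbon ring could give a different answer. From the compounds shown here alone, it also remains open whether an amine or a carboxylic acid at the end of an open chain would give a lower number than the chloro and hydroxy chains.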